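The compounds below may be only part of what the source reports. "The series", "measured", "known", "first", "only" and "open" are said of these compounds alone.

Working notes on the series.

Compound 1 `N=C(NCc1ccccc1)[C@@H]1CCC(=O)N1Cc1ccccc1` is the parent. In a functional assay on SH-SY5Y cells (Homo sapiens) for cytotoxicity, read by MTT assay, with stated times of 8 h, 30 min and 12 h, tested at 0.5 uM (on this read-out lower numbers stand for a weaker effect and higher numbers for a stronger effect at the one concentration tested), compound 1 gives 27.9%. Compound 2 `N=C(NCc1ccc(O)cc1)[C@@H]1CCC(=O)N1Cc1ccccc1` differs from it by hydroxy in place of hydrogen on an aromatic carbon; in this assay compound 2 gives 35.4%, the step being a number 7.5 percentage points higher from compound 1 to compound 2 (within the scatter). Compound 3 `N=C(NCc1ccccc1)[C@@H]1CCC(=O)N1Cc1ccc(F)cc1` differs from compound 1 by fluoro in place of hydrogen on an aromatic carbon; in this assay compound 3 gives 23.3%, the step being a number 4.6 percentage points lower from compound 1 to compound 3 (within the scatter). Among the compounds with values here, compound 3 holds the lowest of the three numbers, its nearest neighbour being compound 1; no direct step between compound 3 and compound 2 is computed here, but their two values show a gap beyond the usual scatter.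

Compound 4 `N=C(NCc1ccc(O)cc1)[C@@H]1CCC(=O)N1Cc1ccc(F)cc1` is not yet measured. Relative to compound 3 it carries hydroxy in place of hydrogen on an aromatic carbon. This is the same change already made once in the series, namely hydroxy in place of hydrogen on an aromatic carbon on compound 1, where it produced the step of a number 7.5 percentage points higher from compound 1 to compound 2 (within the scatter). The two cores on which the change is made differ by fluoro in place of hydrogen on an aromatic carbon; the place of the change reads the same in both pairs, so it is taken as the same change. Within the data shown here, from compound 3 to compound 4 a step of a number 7.7 percentage points higher from compound 3 to compound 4 (within the scatter) is expected in this assay, resting on the earlier step of a number 7.5 percentage points higher from compound 1 to compound 2 (within the scatter) applied to the value of compound 3, 23.3%; with only one precedent, the uncertainty is set wide. Compound 4 is accordingly estimated at 31% in this assay, expected to fall between 21% and 41%.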

Compound 4, a percentage reported as activity, at one concentration (the size of the read-out at that concentration, not a potency): 42%
Compound 4: middle estimate off by 11 percentage points, on the low side; measured number outside the range, above it.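

In this assay, hydroxy in place of hydrogen on the fluorinated core gives a number 18.7 percentage points higher from compound 3 to compound 4 (beyond the scatter), and this step cannot be told apart from the one on the core of compound 1: the same change on two cores in this assay, a number 7.5 percentage points higher (within the scatter) from compound 1 to compound 2 and a number 18.7 percentage points higher (beyond the scatter) from compound 3 to compound 4, 11.2 percentage points apart, within the scatter of two such steps. Read along the other edge of the same square, fluoro in place of hydrogen on the hydroxylated core gives a number 6.6 percentage points higher from compound 2 to compound 4 (within the scatter), and this step likewise cannot be told apart from its earlier counterpart: the same change on two cores in this assay, a number 4.6 percentage points lower (within the scatter) from compound 1 to compound 3 and a number 6.6 percentage points higher (within the scatter) from compound 2 to compound 4, 11.2 percentage points apart, within the scatter of two such steps. Within the data shown here, the four compounds are therefore compatible with a single hydroxy step carried from one core to the other, but they do not show that the fluoro group enlarges that step, even though only the step on the fluorinated core lies beyond the scatter, and two cores cannot establish that the step holds more widely.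

The compounds shown carry only hydroxy and fluoro on the aromatic rings, which leaves open whether methoxy, an amine or a carboxylic acid in the same place would give a step of similar size, and whether a longer chain in place of a benzyl group would leave these steps intact. With one concentration in this assay, the numbers give only the stronger or weaker effect at that concentration and leave open how these compounds would compare at any other concentration.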